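Dipropylamino Replacing Dimethylamino in a Rat Inhibition Assay

The compounds below may be only part of what the source reports. "The series", "measured", "known", "first", "only" and "open" are said of these compounds alone.

Compound 1, `CCNc1c(C)nc2c(OCc3ccccc3)cccn12`: 95%
Compound 2, `Cc1nc2c(OCc3ccccc3)cccn2c1N(C)C`: 76%

Among the measured compounds shown here, in a functional assay on the whole organism with Rattus norvegicus as the target, at a dose of 40 mg/kg by the intraperitoneal route (a lower number here means less inhibition, a higher number more inhibition at the dose given (going by the name of the read-out)), compound 2 stands lowest of the two numbers measured; the only step known is a number 19 percentage points lower from compound 1 to compound 2 (beyond the scatter), a modest fall beyond the scatter. Compound 3, `CCCN(CCC)c1c(C)nc2c(OCc3ccccc3)cccn12`, carries a different change: dipropylamino in place of dimethylamino on an aromatic carbon. For the measured compounds named here, no measured step concerns a longer dialkylamino group, so that one step gives little guidance for this exchange. Compound 3 is therefore expected to give about 70%, within a range from 45% to 90%. That estimate means a number 6 percentage points lower from compound 2 to compound 3 (within the scatter), a step expected to stay within the scatter.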

Compound 3, a percentage reported as inhibition, in the whole organism at one dose (the size of the read-out at that dose, not a potency): 60%
The estimate for compound 3 lay 10 percentage points above the measured number; low and high end bracket the measured number.
By their numbers in this assay, from the lowest: compound 3; then compound 2; then compound 1.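

In this assay, replacing dimethylamino with dipropylamino on this aromatic carbon gives a number 16 percentage points lower from compound 2 to compound 3 (beyond the scatter) and shows that a longer dialkylamino group lowers the inhibition further without abolishing it. Set against ethylamino, dipropylamino gives a number 35 percentage points lower from compound 1 to compound 3 (beyond the scatter) and thus the largest drop among the compounds shown. Nothing available explains this fall. The compounds shown leave open how diethylamino, which lies between the two dialkylamino groups in chain length, or a primary amine would behave at this position. They also leave open whether a ring amine such as morpholine would keep the inhibition.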